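A methyl shifted on the phenyl group

The source may report more compounds than this note shows. Statements on the series, on what has been measured and on what is new or still open speak of the compounds shown alone.

Of the compounds shown here, three sharing one core have been tested in a functional assay on RKE cells for antagonist activity at Vasoactive intestinal polypeptide receptor 1 (Rattus norvegicus), read by HTRF and cAMP accumulation, with stated times of 10 min and 30 min; on this read-out higher numbers stand for weaker inhibition and lower numbers for stronger inhibition. For the measured compounds named here, compound 3 `Cc1ccc(-c2cc(C(C)(C)C)cc(C(C)C)c2CO)cc1` is the only one with an actual number: in this assay compound 3 gives 300 nM. Compound 1 `CC(C)c1cc(C(C)(C)C)cc(-c2cccc(C(F)(F)F)c2)c1CO` gives > 50000 nM, which is a limit of the assay and not a number. Compound 2 `CC(C)c1cc(C(C)(C)C)cc(-c2cccc(C#N)c2)c1CO` likewise gives > 50000 nM, again a limit rather than a number. Because (the limit of > 50000 nM in this assay, at which 2 of the 3 values shown sit), the step that the two limits leave unreadable from compound 1 to compound 2 cannot be read, and compound 3 therefore stands alone as the single readable point.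

Compound 4 `Cc1cccc(-c2cc(C(C)(C)C)cc(C(C)C)c2CO)c1` is the next compound to be measured. It differs from compound 3 by 3-methylphenyl in place of 4-methylphenyl on an aromatic carbon; the two hold the same atoms joined differently, so only the position of the methyl on the phenyl changes. Going by the values given here, none of the measured compounds probes a methylphenyl in either position, and the one measured step concerns a different change and is unreadable. No direction can be drawn from the data for this step. A change of this size between two unmeasured points is expected to stay within the usual scatter, so the estimated step of a 1.3-fold higher number from compound 3 to compound 4 (0.12 log units; within the scatter) is small. Compound 4 is expected to give about 400 nM, with a range from 100 nM to 2000 nM.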

Compound 4, half-maximal inhibitory concentration: 240 nM
Beside the measured number, compound 4's estimate is 1.7-fold (0.22 log units) above it, and the stated range covers the measured number.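

In this assay, moving the methyl around the phenyl group makes no difference that can be told from scatter: the data show a 1.3-fold lower number from compound 3 to compound 4 (0.10 log units; within the scatter), so the 3-methylphenyl and 4-methylphenyl groups cannot be ranked. For the compounds shown here, what the earlier compounds could not show is how much the identity of the group on the phenyl matters, and compound 4 now gives a readable point for comparison, with an at least 200-fold lower number from compound 2 to compound 4 (2.31 log units; beyond the scatter) for methyl in place of cyano and an at least 200-fold lower number from compound 1 to compound 4 (2.31 log units; beyond the scatter) for methyl in place of trifluoromethyl. Across these four compounds, then, swapping the group changes the number far more than shifting the methyl does, and both large steps are only minimum sizes because they start from a limit of the assay rather than a number: the limit of > 50000 nM in this assay, at which 2 of the 4 values shown sit.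

The step between the trifluoromethyl and cyano compounds cannot be read, so those two groups cannot be ordered against each other. The compounds shown also leave open whether methyl is the only group that keeps the number low, as an ethyl, a methoxy or an amine on the phenyl would be needed to test that.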